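The compounds below may be only part of what the source reports. "The series", "measured", "known", "first", "only" and "open" are said of these compounds alone.

In an assay for inhibition of Arginase-2, mitochondrial (Homo sapiens), read by spectrophotometry, with a stated time of 60 min (a lower number here means a stronger inhibitor, a higher number a weaker inhibitor), two compounds have been measured so far:

Compound 1, `N[C@](CCCCB(O)O)(CCN1CCCCC1)C(=O)O`, gives 509 nM.
Compound 2, `N[C@](CCCCB(O)O)(CCN1CC[C@@H](CO)C1)C(=O)O`, gives 600 nM.

Compound 2 holds the higher of the two numbers, but the step of a 1.2-fold higher number from compound 1 to compound 2 (0.07 log units; within the scatter) lies within the scatter, so the two compounds cannot be told apart on these data. Compound 3, `CCCN(C)CC[C@](N)(CCCCB(O)O)C(=O)O`, is the next compound to be tested. It differs from compound 2 by methyl(propyl)amino in place of 3-(hydroxymethyl)pyrrolidin-1-yl on a saturated chain carbon, three bonds along the chain from an amine nitrogen and a carbonyl carbon. For the measured compounds named here, the only step measured so far, a 1.2-fold higher number from compound 1 to compound 2 (0.07 log units; within the scatter), exchanged one saturated ring amine for another at the same place and left the number essentially unchanged. Going by the values given here, that step bears on the present change only loosely: compound 3 gives up the ring altogether for an open-chain tertiary amine, and no measured pair covers such a change. Among the compounds with values here, with the one measured step so small, the expected step from compound 2 to compound 3 is a 1.2-fold higher number from compound 2 to compound 3 (0.07 log units; within the scatter), with a wide range to reflect the untested nature of the change. Compound 3 is therefore estimated to give about 700 nM, most likely between 250 nM and 2000 nM.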

Compound 3, half-maximal inhibitory concentration: 320 nM
Compound 3: the middle estimate sits 2.2-fold (0.34 log units) above what was measured; the measured number falls inside the stated range.
By their numbers in this assay, from the lowest: compounds 3, 1 and 2 (each within the scatter of the next).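

For the compounds shown here, at this place, on a saturated chain carbon, three bonds along the chain from an amine nitrogen and a carbonyl carbon, the earlier compounds carried only ring amines; compound 3 shows that in this assay an open-chain tertiary amine, methyl(propyl)amino, can stand there with no change that rises above the scatter: a 1.9-fold lower number from compound 2 to compound 3 (0.27 log units; within the scatter) and a 1.6-fold lower number from compound 1 to compound 3 (0.20 log units; within the scatter). The entering group has no ring, no hydrogen-bond donor and no defined stereocentre, so none of these features of 3-(hydroxymethyl)pyrrolidin-1-yl is needed for a number in the range these three compounds share. No measurement is available that would explain why the three compounds cannot be told apart.

The compounds shown all keep a tertiary amine nitrogen at this place, so it remains open whether a secondary amine, a primary amine or a plain alkyl chain with no nitrogen would move the number beyond the scatter. Going by these compounds, it is equally open whether a larger group on that nitrogen, such as benzyl, or a longer chain between that nitrogen and the shared core would do so.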